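The compounds below may be only part of what the source reports. "The series", "measured", "known", "first", "only" and "open" are said of these compounds alone.

Working notes on the series. Compound 1 `S=c1[nH]nc(Cc2ccccc2Oc2ccccc2)[nH]1` is the reference point for this step. In a functional assay on the whole organism (strain NMRI) with Mus musculus as the target, with a stated time of 60 min, at a dose of 5 mg/kg by the intraperitoneal route (on this read-out lower numbers stand for a weaker effect and higher numbers for a stronger effect at the one dose given), compound 1 gives 126%. Compound 2 `CSc1nnc(Cc2ccc(Cl)cc2Oc2ccccc2Cl)[nH]1` gives 125% in this assay, and compound 3 `Clc1ccc(Cc2nnc(SCc3ccccc3)[nH]2)c(Oc2ccccc2Cl)c1` gives 113%. Compound 1 holds the highest of the three numbers; its gap to compound 2 lies within the scatter, its gap to compound 3 beyond it. For the measured compounds named here, the only step measured inside the set, a number 12 percentage points lower from compound 2 to compound 3 (beyond the scatter), concerns the group attached to the ring sulfur and not the ring itself.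

Compound 4 `Nc1nnc(Cc2ccccc2Oc2ccccc2)o1` is not yet measured. It differs from compound 1 in one place: a group of 6 heavy atoms (2 carbon, 3 nitrogen, 1 oxygen; one five-membered aromatic ring with 3 hetero atoms) in place of a group of 6 heavy atoms (2 carbon, 3 nitrogen, 1 sulfur; one five-membered aromatic ring with 3 hetero atoms), on a saturated chain carbon bound to an aromatic carbon. Going by the values given here, no measured pair exchanges the five-membered ring, so this change has no direct precedent; the step from compound 2 to compound 3 touches only the sulfur substituent and does not bear on it. Lacking a bearing step, compound 4 is expected to stay near compound 1, with a wide range: a number 11 percentage points lower from compound 1 to compound 4 (beyond the scatter). The estimate for compound 4 is 115%, between 90% and 140%.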

Compound 4, a percentage reported as activity, at one dose (the size of the read-out at that dose, not a potency): 132%
Estimate against measurement, compound 4: 17 percentage points below, within the range that was stated.
By their numbers in this assay, from the lowest: compound 3; then compounds 2, 1 and 4 (each within the scatter of the next).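

For the compounds shown here, the first exchange of the five-membered ring on the saturated chain carbon bound to an aromatic carbon gives a number 6 percentage points higher from compound 1 to compound 4 (within the scatter) in this assay, so the read-out at this one dose does not separate the two groups. The 5-amino-1,3,4-oxadiazol-2-yl group thus carries the read-out as well as the sulfur-bearing group of compound 1, despite its oxygen in place of sulfur and its different counts of hydrogen-bond donors and acceptors. Nothing available accounts for this outcome.

The compounds shown leave open whether the amino group of the oxadiazole matters, as a methyl group or a methylsulfanyl group in its place would test. They also leave open whether a non-ring group such as a carboxylic acid would serve at the same place on the core of compound 1.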